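The compounds below may be only part of what the source reports. "The series", "measured", "known", "first", "only" and "open" are said of these compounds alone.

Compound 1 `C=CCn1c(=O)c(C=O)cc2ccccc21` gives > 100000 nM (a limit)
Compound 2 `C#CCn1c(=O)c(C=O)cc2ccccc21` gives > 100000 nM (a limit)

Both compounds were tested in a functional assay on SK-OV-3 cells (Homo sapiens) for cytotoxicity, read by MTT assay, with a stated time of 24 h (a higher number here means a weaker inhibitor, a lower number a stronger inhibitor), and neither gave a number. Compound 2 stands at > 100000 nM as a limit of the assay, so its place in the series cannot be ranked. The evidence so far is the limit of > 100000 nM in this assay, at which 2 of the 2 values shown sit, and nothing more. Among the compounds with values here, the only measured pair is a step that the two limits leave unreadable from compound 1 to compound 2 and it concerns the chain on the aromatic nitrogen, so it gives no size to carry over.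

Compound 3 `C#CCn1c(=O)c(C=O)cc2cc(Cl)ccc21` keeps the chain of compound 2 and differs by chloro in place of hydrogen on an aromatic carbon. Within the data shown here, no measured step covers a change of this kind. In this assay no step beyond the scatter is therefore expected, in either direction, though this expectation is weakly supported. The expectation starts from compound 2 at > 100000 nM, which is a limit. The expected change is a number no higher from compound 2 to compound 3 (the limit leaves the size open), and another limit would be no surprise. For compound 3 the estimate is 100000 nM, with an expected range from 30000 nM to 300000 nM.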

Compound 3, half-maximal inhibitory concentration: > 100000 nM
Compound 3 gave a limit, no number; the forecaster's own chance of this, stated with the estimate: 65%; the middle value lies on the limit itself.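

In this assay compound 3 gives > 100000 nM, a limit and not a number, so no new step can be read between compound 2 and compound 3. The compounds shown leave open whether the chloro group or the chain on the aromatic nitrogen changes the response in this assay at all.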